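From 4-methylphenyl to 2-methoxyphenyl on the shared core

This account rests on a few compounds, and the source may have more. Where it says the series, first, only, none or still open, it means among the compounds named here.

In a functional assay on ECa-109 cells for inhibition, with ECa-109 cell line (Homo sapiens) as the target, read by sulforhodamine B assay (on this read-out higher numbers stand for weaker inhibition and lower numbers for stronger inhibition), compound 1 (`O=C1C(Nc2ccccc2)=CC(=O)c2c1nc1n2[C@H]2OC[C@@H](O)[C@H]2OC1`) gives 3560 nM as a measured number. Compound 2 (`Cc1ccc(NC2=CC(=O)c3c(nc4n3[C@H]3OC[C@@H](O)[C@H]3OC4)C2=O)cc1`) is reported only as a limit of > 4000 nM and not as a number. Compound 3 (`COc1ccccc1NC1=CC(=O)c2c(nc3n2[C@H]2OC[C@@H](O)[C@H]2OC3)C1=O`) has not yet been measured. Its difference from compound 2 is 2-methoxyphenyl in place of 4-methylphenyl on an amine nitrogen. Within the data shown here, only one measured step bears on this change, and only indirectly: an at least 1.1-fold higher number from compound 1 to compound 2 (0.05 log units; that floor lies within the scatter) for methyl in place of hydrogen on an aromatic carbon. That step is a floor and not a measured size (the limit of > 4000 nM in this assay, at which 1 of the 2 values shown sits). Among the measured compounds shown here, no measured step involves a 2-methoxyphenyl group. For the measured compounds named here, with compound 1 at 3560 nM as the only number, no step beyond the scatter is expected in this assay and no direction is favoured. A report of a limit alone also remains likely. The estimated step is an at least 1.1-fold lower number from compound 2 to compound 3 (0.05 log units; that floor lies within the scatter) and it has a limit at one end. Compound 3 is estimated at 3500 nM with an expected range of 1500 nM to 8000 nM on this read-out.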

Compound 3, half-maximal inhibitory concentration: > 4000 nM
Compound 3: a limit, no number; the forecaster's own chance of this, stated with the estimate: 40%; at least 1.1-fold (0.05 log units) between middle value and limit.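

In this assay, the 2-methoxyphenyl group on the amine nitrogen leaves compound 3 as a limit and not a number, as the 4-methylphenyl group did for compound 2, so the step between these two compounds cannot be read. Among these compounds, the one readable comparison for the new group is an at least 1.1-fold higher number from compound 1 to compound 3 (0.05 log units; that floor lies within the scatter), so it gives a floor within the scatter and no measured size, as the methyl change did before it. With a second substituted aryl group reported this way, limits now make up most of the series, and the read-out at this position is set by the assay's ceiling and not by measured differences: the limit of > 4000 nM in this assay, at which 2 of the 3 values shown sit.

Among the compounds shown here, the size of any effect of methyl or methoxy on the aryl group therefore stays open, as does whether any change on this ring gives a number clearly lower than the one measured value, where compound 1 gives 3560 nM. Also open, on these data alone, is how a chlorine atom, a carboxylic acid or a dimethylamino group on the same ring would read in this assay.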